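Aromatic nitrogen substituents: from compound 3 to compound 4

This account rests on a few compounds, and the source may have more. Where it says the series, first, only, none or still open, it means among the compounds named here.

Values in a functional assay on HT-29 cells (Homo sapiens) for inhibition, read by luminescence and CellTiter-Glo, with a stated time of 24 h; a lower number here means that less compound is needed, a higher number that more compound is needed for the effect:
- compound 1 `COCCn1nc(C(=O)N[C@H]2COc3ccccc3N(C)C2=S)nc1Cc1ccccc1`: 566 nM
- compound 2 `CN1C(=S)[C@@H](NC(=O)c2nc(Cc3ccccc3)n(C3COC3)n2)COc2ccccc21`: 916 nM
- compound 3 `CN1C(=S)[C@@H](NC(=O)c2nc(Cc3ccccc3)n(C3CCOCC3)n2)COc2ccccc21`: 2260 nM

Compound 3 stands highest of the three on these numbers. Compound 4 `CN1C(=S)[C@@H](NC(=O)c2nc(Cc3ccccc3)n(C3CCN(C(=O)OC(C)(C)C)C3)n2)COc2ccccc21` differs from it by a group of 12 heavy atoms (9 carbon, 1 nitrogen, 2 oxygen; one five-membered non-aromatic ring with 1 hetero atom) in place of a group of 6 heavy atoms (5 carbon, 1 oxygen; one six-membered non-aromatic ring with 1 hetero atom), on an aromatic nitrogen at the same place. Three measured changes on that nitrogen bear on this: a 1.6-fold higher number from compound 1 to compound 2 (0.21 log units; within the scatter) is small, while a 4.0-fold higher number from compound 1 to compound 3 (0.60 log units; beyond the scatter) and a 2.5-fold higher number from compound 2 to compound 3 (0.39 log units; beyond the scatter) are modest. Within the data shown here, no measured compound carries the entering group, so these steps are only a rough guide. In this assay no step beyond the scatter is expected, with a higher number somewhat likelier than a lower one. The estimated change is a 1.3-fold higher number from compound 3 to compound 4 (0.12 log units; within the scatter) on this reasoning. For compound 4 the estimated value is 3000 nM with an expected range of 1000 nM to 9000 nM in this assay.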

Compound 4, half-maximal effective concentration: > 10000 nM
Compound 4: no number, only a limit; the forecaster's own chance of this, stated with the estimate: 5%; middle value at least 3.3-fold (0.52 log units) away from the limit.
By their numbers in this assay, from the lowest: compounds 1 and 2 (each within the scatter of the next); then compound 3. At a limit, above all of these: compound 4.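

In this assay compound 4 gives > 10000 nM, which is a limit and not a number. With the group of 12 heavy atoms on the aromatic nitrogen, the steps are an at least 4.4-fold higher number from compound 3 to compound 4 (0.64 log units; beyond the scatter), an at least 10-fold higher number from compound 2 to compound 4 (1.03 log units; beyond the scatter) and an at least 17-fold higher number from compound 1 to compound 4 (1.24 log units; beyond the scatter). This position therefore allows a far larger shift than the three smaller groups showed among themselves, and each step gives only a lower bound on its size.

The compounds shown leave open whether the higher number goes with the five-membered ring itself or with what its nitrogen carries. A free secondary amine or an acetyl group at that ring nitrogen would separate the two.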